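Benzylaminoalkyl sulfonamide series: growth inhibition notes

The source may report more compounds than this note shows. Statements on the series, on what has been measured and on what is new or still open speak of the compounds shown alone.

Measured in a toxicity assay on MCF-10A cells (Homo sapiens) for inhibition, read by MTT assay, with a stated time of 72 h; on this read-out higher numbers stand for weaker inhibition of growth and lower numbers for stronger inhibition of growth:
- compound 1 `CC(C)(C)c1ccc(CNCCNS(=O)(=O)c2cc(C(F)(F)F)cc(C(F)(F)F)c2)cc1` gives 14000 nM
- compound 2 `COc1cccc(CNCCCNS(=O)(=O)c2cc(C(F)(F)F)cc(C(F)(F)F)c2)c1` gives 6600 nM
- compound 3 `O=S(=O)(NCCCNCc1ccc(-c2ccccc2)cc1)c1cc(C(F)(F)F)cc(C(F)(F)F)c1` gives 2800 nM

On these numbers compound 2 stands second highest of the three. Its nearest neighbour is compound 1, whose number is higher by a margin that lies beyond the usual scatter; compound 3 stands furthest from it, with a lower number, again beyond the scatter. Within the data shown here, no pair among the measured compounds differs in a single place, so no measured step is available for guidance.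

Compound 4 `O=S(=O)(NCCCNCc1ccc(Cl)c(Cl)c1)c1cc(C(F)(F)F)cc(C(F)(F)F)c1` has not yet been measured in this assay. It differs from compound 2 in one place: 3,4-dichlorophenyl in place of 3-methoxyphenyl on a saturated chain carbon bound to an amine nitrogen.

Among the measured compounds shown here, the data give no step to build on, so the expectation for compound 4 rests on the spread of the three measured values. A modest move from compound 2 toward lower numbers is expected, with the step of a 1.7-fold lower number from compound 2 to compound 4 (0.22 log units; within the scatter) possibly not reaching beyond the scatter. Compound 4 is expected to give about 4000 nM in this assay, estimated to fall between 1500 nM and 11000 nM.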

Compound 4, concentration for 50% growth inhibition: 3000 nM
Compound 4: middle estimate off by 1.3-fold (0.12 log units), on the high side; the measured number falls inside the stated range.
By their numbers in this assay, from the lowest: compounds 3 and 4 (each within the scatter of the next); then compound 2; then compound 1.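

In this assay, the saturated chain carbon bound to an amine nitrogen now has its first measured step: 3,4-dichlorophenyl in place of 3-methoxyphenyl gives a 2.2-fold lower number from compound 2 to compound 4 (0.34 log units; beyond the scatter) with the rest of the structure unchanged. The earlier compounds shown here could not show this, as no two of compound 1, compound 2 and compound 3 differ in one place, so the aryl group at this place is now seen to shift the growth-inhibition number beyond the scatter. No measured evidence bears on the reason for this step.

Still open, as far as these compounds go, is whether a single chlorine, a nitrile or a carboxylic acid on this phenyl ring would shift the number in the same direction. Also open, from the compounds shown here alone, is whether the same change gives a similar step on a longer chain.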